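This account rests on a few compounds, and the source may have more. Where it says the series, first, only, none or still open, it means among the compounds named here.

Measured so far:
compound 1 `COc1ccc(NCN2C(=O)c3ccccc3C2=O)cc1` — in an assay on isolated protein for inhibition of ribosomal protein S6 kinase alpha-2 (Homo sapiens), read by fluorescence, with a stated time of 20 min (on this read-out higher numbers stand for weaker inhibition and lower numbers for stronger inhibition), compound 1 gives 470 nM
compound 2 `O=C1c2ccccc2C(=O)N1CNc1ccc(O)cc1` — in this assay compound 2 gives 520 nM

Compound 1 has the lowest of the two numbers recorded so far; its nearest neighbour is compound 2, and the step of a 1.1-fold higher number from compound 1 to compound 2 (0.04 log units; within the scatter) lies within the scatter, so no order between the two can be claimed. That step is hydrogen in place of methyl on an oxygen on an aromatic ring, a change on the outer ring, not on the shared core.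

Compound 3 `COc1ccc(NCN2C(=O)c3ccc(N)cc3C2=O)cc1` is the next candidate. Relative to compound 1 the change is amino in place of hydrogen on an aromatic carbon of the fused ring of the core. Within the data shown here, no measured step touches that ring; the only step recorded, a 1.1-fold higher number from compound 1 to compound 2 (0.04 log units; within the scatter), concerns a different part of the molecule and was itself within the scatter. There is therefore no basis for expecting a step beyond the scatter, and the estimate is correspondingly wide. Compound 3 is expected to give 400 nM (range 150 nM to 1200 nM) in this assay. This corresponds to an expected step of a 1.2-fold lower number from compound 1 to compound 3 (0.07 log units; within the scatter), essentially none beyond the scatter.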

Compound 3, half-maximal inhibitory concentration: 590 nM
The estimate for compound 3 lay 1.5-fold (0.17 log units) below the measured number; low and high end bracket the measured number.
By their numbers in this assay, from the lowest: compounds 1, 2 and 3 (each within the scatter of the next).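

In this assay the series now has a reading on the fused ring of the shared core, where amino in place of hydrogen gives a 1.3-fold higher number from compound 1 to compound 3 (0.10 log units; within the scatter) and so no change that can be told from the scatter. This aromatic carbon therefore carries a heavy atom in place of hydrogen without a readable gain or loss, something the earlier step on the outer ring could not show. No measurement in hand bears on why the number stays within the scatter here.

On these data alone, whether the same holds for other groups on this aromatic carbon, such as a carboxylic acid, an acetamide or a longer aminoalkyl chain, remains open. Also open, as far as these compounds go, is how amino would read on the other aromatic carbons of this ring, or with hydroxy in place of methoxy on the outer ring.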